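Tetradecyl threonine amides: swapping the acyl cap

The source may report more compounds than this note shows. Statements on the series, on what has been measured and on what is new or still open speak of the compounds shown alone.

Measured so far:
compound 1 `C/C=C/C=C/C(=O)N[C@H](C(=O)NCCCCCCCCCCCC)[C@@H](C)O`: > 400000 nM
compound 2 `CCCCCCCCCCCCCCNC(=O)[C@@H](NC(=O)c1ccco1)[C@@H](C)O`: > 400000 nM
compound 3 `CCCCCCCCCCCCCCNC(=O)[C@@H](NC(=O)c1nccc2ccccc12)[C@@H](C)O`: 28600 nM

In a functional assay on HepG2 cells (Homo sapiens) for cytotoxicity, read by MTT assay, with a stated time of 48 h (on this read-out lower numbers stand for stronger inhibition and higher numbers for weaker inhibition), compound 1 gives only a limit, > 400000 nM. Compound 2 likewise gives only a limit, > 400000 nM. Among the compounds with values here, compound 3 is the sole compound with a number, 28600 nM; the other two sit at the limit of > 400000 nM in this assay, at which 2 of the 3 values shown sit. Within the data shown here, the one step in hand, an at least 13-fold lower number from compound 2 to compound 3 (1.14 log units; beyond the scatter), shows a large gain on moving to the bicyclic cap. Compound 4 `C/C=C/C=C/C(=O)N[C@H](C(=O)NCCCCCCCCCCCCCC)[C@@H](C)O` reverses that direction: penta-1,3-dien-1-yl in place of isoquinolin-1-yl on a carbonyl carbon. Compound 1, carrying the same penta-1,3-dien-1-yl cap on a shorter chain, gives only a limit. A large weakening is therefore expected, a 12-fold higher number from compound 3 to compound 4 (1.09 log units; beyond the scatter), most likely back to a limit. Compound 4 is estimated at 350000 nM (range 80000 nM to 1500000 nM).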

Compound 4, half-maximal inhibitory concentration: > 400000 nM
Compound 4: a limit, no number; the forecaster's own chance of this, stated with the estimate: 70%; middle value at least 1.1-fold (0.05 log units) away from the limit.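

With the tetradecyl chain held fixed, replacing the group on the carbonyl carbon alone produces a large change, and the size printed is a bound because compound 4 gives only a limit: an at least 13-fold higher number from compound 3 to compound 4 (1.14 log units; beyond the scatter). On this chain, isoquinolin-1-yl is now the only cap shown that gives a number rather than a limit: the limit of > 400000 nM in this assay, at which 3 of the 4 values shown sit. The steps from compound 1 and compound 2 to compound 4 cannot be read, as both ends are limits. Open, from the compounds shown here alone, is whether a phenyl or naphthalen-1-yl cap on the same chain would also give a number.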